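Moving the chlorine around the ring in a thiazole-pyrimidinone series

The source may hold more compounds than are shown below. What is called first, only, known or untested is meant among the compounds shown, and "the series" means these compounds.

In a functional assay on U-87MG ATCC cells for antiproliferative activity against U-87 MG (Homo sapiens), read by MTT assay, with a stated time of 48 h, tested at 50 uM (a lower number here means a stronger effect, a higher number a weaker effect of the compound at the concentration tested), compound 3 `Cc1nc(-c2ccccc2)sc1C(=O)CSc1nc(-c2cccc(Cl)c2)c(C#N)c(=O)[nH]1` gives 50.6%, the lowest of the three numbers measured. Compound 2 `Cc1nc(-c2ccc(Cl)cc2)sc1C(=O)CSc1nc(-c2ccc(Cl)cc2)c(C#N)c(=O)[nH]1` gives 60%, within the scatter of compound 3, while compound 1 `Cc1nc(-c2ccccc2)sc1C(=O)CSc1nc(-c2ccccc2)c(C#N)c(=O)[nH]1` gives 77.5%, beyond it. For the measured compounds named here, the one single-point step known is a number 26.9 percentage points lower from compound 1 to compound 3 (beyond the scatter). Compound 4 `Cc1nc(-c2ccccc2)sc1C(=O)CSc1nc(-c2ccc(Cl)cc2)c(C#N)c(=O)[nH]1` differs from compound 3 by 4-chlorophenyl in place of 3-chlorophenyl on an aromatic carbon. Going by the values given here, no measured step compares the two chlorophenyl isomers directly; compound 2, which carries 4-chlorophenyl at two sites, reads close to compound 3, and the step from compound 1 shows that the chlorine itself lowers the read-out. Compound 4 is therefore expected near compound 3, with a number 6.4 percentage points higher from compound 3 to compound 4 (within the scatter) small and inside the scatter, giving an estimate of 57% in this assay, ranging from 44% to 72%.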

Compound 4, a percentage reported as activity, at one concentration (the size of the read-out at that concentration, not a potency): 63.4%
Beside the measured number, compound 4's estimate is 6.4 percentage points below it, and the stated range covers the measured number.
By their numbers in this assay, from the lowest: compounds 3, 2 and 4 (each within the scatter of the next, the first and the last beyond it); then compound 1.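

Where the chlorine sits on this ring matters in this assay: 4-chlorophenyl in place of 3-chlorophenyl gives a number 12.8 percentage points higher from compound 3 to compound 4 (beyond the scatter), though the chlorine at the new site still counts, with a number 14.1 percentage points lower from compound 1 to compound 4 (beyond the scatter). Removing one chlorine from the doubly chlorinated compound gives only a number 3.4 percentage points higher from compound 2 to compound 4 (within the scatter). The same change of hydrogen to chloro is therefore not worth the same on both cores: the same change on two cores in this assay, a number 26.9 percentage points lower (beyond the scatter) from compound 1 to compound 3 and a number 3.4 percentage points lower (within the scatter) from compound 4 to compound 2, 23.5 percentage points apart, beyond the scatter of two such steps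

Going by these compounds, whether a bromine, a methoxy group or an amine in place of the chlorine would follow the 3-chlorophenyl or the 4-chlorophenyl reading remains open. These single-concentration read-outs also give no potency.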